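Cytotoxicity limits across a biaryl amide acid series

The source may hold more compounds than are shown below. What is called first, only, known or untested is meant among the compounds shown, and "the series" means these compounds.

Measured compounds:
compound 1, `CC(C)N(Cc1cccc(OCCCCCC(=O)O)c1)C(=O)c1ccc(-c2cccc(N(C)C)c2)cc1`: in an ADME assay on Raji cells (Homo sapiens) for cytotoxicity, read by CellTiter-Glo and resazurin assay, with a stated time of 72 h (a higher number here means that more compound is needed for the effect, a lower number that less compound is needed), compound 1 gives > 26000 nM, a limit of the assay.
compound 2, `CC(C)N(Cc1cccc(OCCCCCC(=O)O)c1)C(=O)c1ccc(-c2cccc(-c3ccccc3)c2)cc1`: in this assay compound 2 gives > 26000 nM, a limit of the assay.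
compound 3, `CC(C)N(Cc1cccc(OCCCCCC(=O)O)c1)C(=O)c1ccc(-c2cccc(OC(F)(F)F)c2)cc1`: in this assay compound 3 gives > 26000 nM, a limit of the assay.

Compound 3 thus stands at the limit of > 26000 nM in this assay, at which 3 of the 3 values shown sit, with no number of its own. The steps a step that the two limits leave unreadable from compound 1 to compound 2, a step that the two limits leave unreadable from compound 1 to compound 3 and a step that the two limits leave unreadable from compound 2 to compound 3 stay unreadable, so none of them tells how the distal ring substituent moves this read-out. Compound 4, `CC(C)N(Cc1cccc(OCCCCCC(=O)O)c1)C(=O)c1ccc(-c2c[nH]c3ccccc23)cc1`, differs from compound 3 by 1H-indol-3-yl in place of 3-(trifluoromethoxy)phenyl on an aromatic carbon. With every measured step unreadable, no step beyond the scatter can be expected in this assay in either direction. Compound 4 is estimated at 30000 nM, with a range from 10000 nM to 100000 nM. The estimated step that the limit leaves unreadable from compound 3 to compound 4 is expected to sit within the scatter, most likely reported again only as a limit.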

Compound 4, half-maximal effective concentration: > 26000 nM
Compound 4: no number, only a limit; the forecaster's own chance of this, stated with the estimate: 80%; the middle value is on the limit's open side.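

Among the compounds shown here, no step to compound 4 from compound 1, compound 2 or compound 3 can be read in this assay, as all four values are limits: the limit of > 26000 nM in this assay, at which 4 of the 4 values shown sit. Going by these compounds, whether any group in this place on the shared core can shift this read-out stays open.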